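Aryl change on the sulfonyl sulfur: compound 1 to compound 4

The compounds below may be only part of what the source reports. "The series", "measured", "known", "first", "only" and "open" are said of these compounds alone.

Measured in an assay on isolated protein for displacement of a labelled ligand from prostaglandin E2 receptor EP3 subtype (Homo sapiens), read by scintillation counting, with a stated time of 2 h; a lower number here means a stronger inhibitor, a higher number a weaker inhibitor:
compound 1 `COc1ccc(S(=O)(=O)NC(=O)NC/C=C2\CCCc3cnn(Cc4ccc(Cl)cc4Cl)c32)cc1`: 10 nM
compound 2 `Cc1ncc(S(=O)(=O)NC(=O)NC/C=C2\CCCc3cnn(Cc4ccc(Cl)cc4Cl)c32)s1`: 7 nM
compound 3 `CS(=O)(=O)c1ccc(-n2ncc3c2/C(=C/CNC(=O)NS(=O)(=O)c2cc(Cl)c(Cl)s2)CCC3)cc1`: 1 nM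

Compound 1 carries the highest of the three numbers. Compound 2 is nearest, with a 1.4-fold lower number from compound 1 to compound 2 (0.15 log units; within the scatter), a change within the scatter. Compound 3 is furthest; its number against that of compound 1 is a gap beyond the scatter, but compound 3 differs in several places at once, so no single step can be read from it.

Compound 4 `COc1ccccc1S(=O)(=O)NC(=O)NC/C=C1\CCCc2cnn(Cc3ccc(Cl)cc3Cl)c21` has not been measured. It differs from compound 1 by 2-methoxyphenyl in place of 4-methoxyphenyl on a sulfonyl sulfur. Going by the values given here, only the step from compound 1 to compound 2 touches the same place, and it shows that exchanging the group on the sulfonyl sulfur left the number within the scatter. Among the compounds with values here, no measured step shifts the methoxy around the ring. For compound 4 in this assay the expectation is therefore no step beyond the scatter, a 1.5-fold higher number from compound 1 to compound 4 (0.18 log units; within the scatter), estimated at 15 nM with a range from 5 nM to 45 nM.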

Compound 4, inhibition constant: 62 nM
Compound 4: middle estimate off by 4.1-fold (0.62 log units), on the low side; the measured number lies above the stated range.
By their numbers in this assay, from the lowest: compound 3; then compounds 2 and 1 (each within the scatter of the next); then compound 4.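

Moving the methoxy group on the ring attached to the sulfonyl sulfur gives a 6.2-fold higher number from compound 1 to compound 4 (0.79 log units; beyond the scatter) in this assay, so this position is sensitive to an isomeric change, which the aryl exchange in a 1.4-fold lower number from compound 1 to compound 2 (0.15 log units; within the scatter) did not reveal. The 2-methoxyphenyl group also compares poorly with the 2-methyl-1,3-thiazol-5-yl group, with an 8.9-fold higher number from compound 2 to compound 4 (0.95 log units; beyond the scatter). No available measurement bears on why the number rises.

Open, going by these compounds, is whether unsubstituted phenyl would stay close to compound 1 or to compound 4. Also open, on these data alone, is how an amine or a hydroxy group in place of the methoxy would behave on the same ring.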